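Acetoxy Added to the Acetamido Chain of Compound 3

A few compounds are considered here, and "the series" means these few. Any claim that something is new, unique, unknown or untested is made for them only; others in the source may bear on it.

Of the compounds shown here, three sharing one core have been measured in an ADME assay on cells for inhibition of Amine oxidase [flavin-containing] A (Homo sapiens), read by fluorescence and Amplex Red, with stated times of 30 min and 15 min; on this read-out lower numbers stand for stronger inhibition and higher numbers for weaker inhibition. Compound 1 `C#CCNC1CCc2c(NCc3ccc(C)cc3)cccc21` gives 43100 nM, compound 2 `C#CCNC1CCc2c(SCc3ccc(Cl)cc3)cccc21` gives 230 nM, and compound 3 `C#CCNC1CCc2c(OCCc3cc(NC(C)=O)ccc3Cl)cccc21` gives 85200 nM. Compound 3 thus shows the highest number of the three; its gap to compound 1 lies within the scatter, so no order between those two can be claimed, whereas compound 2 stands well beyond the scatter with the lowest number. Compound 4 `C#CCNC1CCc2c(OCCc3cc(NC(=O)COC(C)=O)ccc3Cl)cccc21` differs from compound 3 by acetoxy in place of hydrogen on a saturated chain carbon bound to a carbonyl carbon. Among the compounds with values here, no pair among the measured compounds isolates this kind of change, so nothing measured here indicates its direction. With that in mind, compound 4 is expected to stay close to compound 3 in this assay, with a step of a 1.1-fold higher number from compound 3 to compound 4 (0.02 log units; within the scatter) that should lie within the scatter of repeated runs. Compound 4 is therefore estimated at 90000 nM, within a range from 30000 nM to 300000 nM.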

Compound 4, half-maximal inhibitory concentration: 437000 nM
Compound 4: the middle estimate sits 4.9-fold (0.69 log units) below what was measured; measured number outside the range, above it.
By their numbers in this assay, from the lowest: compound 2; then compounds 1 and 3 (each within the scatter of the next); then compound 4.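

In this assay, the saturated chain carbon bound to a carbonyl carbon turns out not to be indifferent to substitution: acetoxy in place of hydrogen there comes with a 5.1-fold higher number from compound 3 to compound 4 (0.71 log units; beyond the scatter). This is the first change in one place among the compounds shown, and it moves towards weaker inhibition, starting from a compound that already stood at the weak end of the earlier set. Nothing available accounts for the size or direction of this step.

As far as these compounds go, whether the step belongs to acetoxy itself or would follow any group on this carbon remains open, and a hydroxyl, an amine or a longer chain at the same place would help to separate the two. Also open, from the compounds shown here alone, is whether acetoxy would act the same way on the side chain of compound 2.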